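Fluorinated benzyl variant on the pyrazole-linked core

The source may report more compounds than this note shows. Statements on the series, on what has been measured and on what is new or still open speak of the compounds shown alone.

Three compounds of this series share one core and differ only in the aryl group that sits on a saturated chain carbon bound to an aromatic nitrogen. In an in vitro assay on HEK293 cells for displacement of a labelled ligand from adenosine receptor A2b (Homo sapiens) (on this read-out lower numbers stand for stronger inhibition and higher numbers for weaker inhibition), compound 1 `CCCn1c(=O)c2nc(-c3cnn(Cc4cccc(C)c4)c3)[nH]c2n(CCC)c1=O` gives 36 nM, compound 2 `CCCn1c(=O)c2nc(-c3cnn(Cc4ccc(F)cc4F)c3)[nH]c2n(CCC)c1=O` gives 700 nM, and compound 3 `CCCn1c(=O)c2nc(-c3cnn(Cc4ccccc4C)c3)[nH]c2n(CCC)c1=O` gives 33 nM. Compound 3 has the lowest of the three numbers; the steps of a 1.1-fold lower number from compound 1 to compound 3 (0.04 log units; within the scatter) and a 21-fold lower number from compound 2 to compound 3 (1.33 log units; beyond the scatter) show that it sits together with compound 1 and well apart from compound 2.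

Compound 4 `CCCn1c(=O)c2nc(-c3cnn(Cc4ccc(F)c(C(F)(F)F)c4)c3)[nH]c2n(CCC)c1=O` is not yet measured. It differs from compound 3 by 4-fluoro-3-(trifluoromethyl)phenyl in place of 2-methylphenyl on a saturated chain carbon bound to an aromatic nitrogen. Within the data shown here, the steps that bear on this are a 19-fold higher number from compound 1 to compound 2 (1.29 log units; beyond the scatter) and a 21-fold lower number from compound 2 to compound 3 (1.33 log units; beyond the scatter): the one fluorinated aryl in the set, in compound 2, gave a number far beyond the scatter relative to both methyl-bearing aryls. Among the measured compounds shown here, compound 4 carries a fluorinated aryl again, with a trifluoromethyl added, but no compound with this exact group is known here, so the step is expected to be upward and large, though smaller than those two steps is possible. For compound 4 the estimate in this assay is 300 nM, within 80 nM to 1200 nM, which amounts to an expected step of a 9.1-fold higher number from compound 3 to compound 4 (0.96 log units; beyond the scatter).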

Compound 4, inhibition constant: 640 nM
Beside the measured number, compound 4's estimate is 2.1-fold (0.33 log units) below it; the range from low to high includes it.
By their numbers in this assay, from the lowest: compounds 3 and 1 (each within the scatter of the next); then compounds 4 and 2 (each within the scatter of the next).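

At this position on a saturated chain carbon bound to an aromatic nitrogen, a second fluorinated aryl now falls with the first in this assay: 4-fluoro-3-(trifluoromethyl)phenyl and 2,4-difluorophenyl cannot be told apart, with a 1.1-fold lower number from compound 2 to compound 4 (0.04 log units; within the scatter). Against the methyl-bearing aryls the new group gives a 19-fold higher number from compound 3 to compound 4 (1.29 log units; beyond the scatter) and an 18-fold higher number from compound 1 to compound 4 (1.25 log units; beyond the scatter), so among these four compounds the two methylphenyl groups form a low pair and the two fluorinated aryls a high pair, and no compound goes against this split. The larger group, with its added trifluoromethyl and four fluorine atoms, therefore brings no measurable separation from the difluorinated aryl, and nothing at hand gives a reason for the split between the pairs.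

The four aryls cannot show whether the high numbers go with the fluorine atoms themselves or with the absence of a methyl group, since every fluorinated aryl here also lacks a methyl. Open too, on these data alone, is where an unsubstituted phenyl, a phenyl carrying one fluorine and one methyl, or a phenyl carrying a methoxy group or an amine would fall in this assay.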